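The compounds below may be only part of what the source reports. "The series", "measured", "known", "first", "only" and "open" are said of these compounds alone.

Compound 1 `O=C(O)CCSC(=S)NCc1cccnc1`: 7970 nM; compound 2 `NC(=O)CCSC(=S)NCc1cccnc1`: 1160 nM.

Among the measured compounds shown here, in a functional assay on SK-BR-3 cells (Homo sapiens) for cytotoxicity, read by resazurin assay, with a stated time of 72 h (on this read-out lower numbers stand for stronger inhibition and higher numbers for weaker inhibition), compound 2 gives the lowest of the two numbers; the only measured step, a 6.9-fold lower number from compound 1 to compound 2 (0.84 log units; beyond the scatter), separates it from compound 1. Compound 3 `S=C(NCc1cccnc1)SCCc1nnn[nH]1` carries 1H-tetrazol-5-yl in place of carbamoyl on a saturated chain carbon, two bonds along the chain from a sulfur. For the measured compounds named here, no measured step covers this exchange, so the one step above is only a loose guide, and it shows that altering this chain end can move the number beyond the scatter in either direction. A modest move back toward higher numbers is expected, as a 2.2-fold higher number from compound 2 to compound 3 (0.33 log units; beyond the scatter). Compound 3 is therefore estimated at 2500 nM, within 600 nM to 10000 nM.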

Compound 3, half-maximal inhibitory concentration: > 100000 nM
Compound 3: only a limit was reported (the forecaster's own chance of this, stated with the estimate: 5%); middle value at least 40-fold (1.60 log units) away from the limit.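

Compound 3 stands only as a limit, not as a number: the limit of > 100000 nM in this assay, at which 1 of the 3 values shown sits. Even so, this chain end turns out to tolerate far less than the earlier pair suggested: 1H-tetrazol-5-yl in place of carbamoyl gives an at least 86-fold higher number from compound 2 to compound 3 (1.93 log units; beyond the scatter), and in place of carboxy it gives an at least 12-fold higher number from compound 1 to compound 3 (1.09 log units; beyond the scatter). Both steps are large, so the five-membered aromatic ring at this place costs more than the modest exchange of hydroxy for amino on the carbonyl carbon.

Still open, on these data alone, is where a methyl ester or a primary amine at this chain end would fall. Also open, as far as these compounds go, is whether a longer chain would bring the 1H-tetrazol-5-yl back to a measurable number.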